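A few compounds are considered here, and "the series" means these few. Any claim that something is new, unique, unknown or untested is made for them only; others in the source may bear on it.

Three members of the series have so far been run in an ADME assay on HeLa cells (Homo sapiens) for cytotoxicity, read by ATP content, with a stated time of 3 days; on this read-out higher numbers stand for lower toxicity in this test and lower numbers for higher toxicity in this test. Compound 1 `CS(=O)(=O)CCCn1c(Cn2c(=O)n(C3CC3)c3ccncc32)nc2nc(Cl)ccc21` gives > 50000 nM, which is a limit of the assay rather than a number. Compound 2 `CC1(n2c(=O)n(Cc3cc4cc(Cl)ccc4n3CCCS(C)(=O)=O)c3cnccc32)CC1` likewise gives > 50000 nM, again a limit. Compound 3 `O=c1n(Cc2cc3ccc(Cl)cc3n2CCCCO)c2cnccc2n1C1CC1` gives > 50000 nM, also a limit. Compound 2 thus stands where every measured member stands: no number is known for it, only the limit described by the limit of > 50000 nM in this assay, at which 3 of the 3 values shown sit. Going by the values given here, no step between measured compounds can be drawn; each pair differs in more than one place.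

Compound 4 `CS(=O)(=O)CCCn1c(Cn2c(=O)n(CC3CC3)c3ccncc32)cc2cc(Cl)ccc21` is next to be measured in this assay. Against compound 2 the change is cyclopropylmethyl in place of 1-methylcyclopropyl on an aromatic nitrogen. Among the compounds with values here, with every value so far sitting at the same limit, the step that is expected, a number no higher from compound 2 to compound 4 (the limit leaves the size open), is none beyond the scatter. Compound 4 is accordingly expected near 50000 nM, within 25000 nM to 100000 nM, and most probably it too will be reported only as a limit.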

Compound 4, half-maximal cytotoxic concentration: > 50000 nM
Compound 4 gave a limit, no number; the forecaster's own chance of this, stated with the estimate: 85%; the middle value lies on the limit itself.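

Going by these compounds alone, compound 2 and compound 4 both stand at a limit of the assay in this assay, so no step between them can be read. The compounds shown leave open how cyclopropylmethyl and 1-methylcyclopropyl on an aromatic nitrogen compare, and whether any member of the series gives a number rather than a limit in this assay.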